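This account rests on a few compounds, and the source may have more. Where it says the series, first, only, none or still open, it means among the compounds named here.

Compound 1 `C=CCONC(=O)CN1C(=O)S/C(=C\c2ccccc2)C1=O`: > 128000 nM
Compound 2 `CC(C(=O)NOCc1ccccc1)N1C(=O)S/C(=C\c2ccccc2)C1=O`: > 128000 nM
Compound 3 `C=CCONC(=O)C(C)N1C(=O)S/C(=C\c2ccccc2)C1=O`: not yet measured

Both values come from an ADME assay on RAW264.7 cells (Mus musculus) for cytotoxicity, read by neutral red uptake, with a stated time of 24 h; a lower number here means that less compound is tolerated, a higher number that more compound is tolerated. Compound 2 gives > 128000 nM, which is a limit of the assay and not a number. Compound 1 gives > 128000 nM, also a limit. The two compounds therefore share one ceiling: the limit of > 128000 nM in this assay, at which 2 of the 2 values shown sit.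

The change to compound 3 is vinyl in place of phenyl on a saturated chain carbon bound to an oxygen, which turns benzyloxy into allyloxy. Within the data shown here, no step between measured compounds is available to size this change. However, compound 1 already carries allyloxy and gives > 128000 nM, so no shift beyond the scatter is expected in this assay, in either direction. The expected step is a number no higher from compound 2 to compound 3 (the limit leaves the size open). The estimate for compound 3 is 128000 nM, with an expected range of 64000 nM to 256000 nM.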

Compound 3, half-maximal cytotoxic concentration: > 128000 nM
Compound 3 ended at the assay's limit; the forecaster's own chance of this, stated with the estimate: 85%; the middle value lies on the limit itself.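

No step can be read from compound 2 to compound 3 or from compound 1 to compound 3, because in this assay all three compounds stop at one assay limit: the limit of > 128000 nM in this assay, at which 3 of the 3 values shown sit. The compounds shown leave open whether vinyl in place of phenyl, or methyl in place of hydrogen, changes how much compound is tolerated, and by how much.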